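Methoxy in Place of Hydrogen: Expected Half-Life

A few compounds are considered here, and "the series" means these few. Any claim that something is new, unique, unknown or untested is made for them only; others in the source may bear on it.

The account follows the step from compound 3 to compound 4. Compound 3 `C=C(C)C(=O)Nc1ccccc1` in an ADME assay for pharmacokinetics, read by LC-MS, in phosphate buffer, with a stated time of 120 min, at pH 7.4, tested at 1 uM, in the presence of a further agent that is not named here (a higher number here means that the compound lasts longer, a lower number that the compound disappears faster), gives > 8.53 h, which is a limit of the assay and not a number. Compound 1 `C=C(CCO)C(=O)Nc1ccccc1` in this assay gives > 8.53 h, again a limit. Compound 2 `C/C=C/C(=O)Nc1ccccc1` in this assay gives > 8.53 h, also a limit. All three values sit at the limit of > 8.53 h in this assay, at which 3 of the 3 values shown sit, so compound 3 stands where the other two stand, at the limit itself. The two steps that reach compound 3 are therefore not readable in size: a step that the two limits leave unreadable from compound 1 to compound 3 and a step that the two limits leave unreadable from compound 2 to compound 3 are both left undetermined by the two limits.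

Compound 4 `C=C(COC)C(=O)Nc1ccccc1` differs from compound 3 by methoxy in place of hydrogen on a saturated chain carbon bound to a double-bonded chain carbon. Within the data shown here, the change is a small one on the side chain, and the only related step on record, from a hydroxymethyl on that same carbon to hydrogen, gave no readable size. The expectation for this assay is thus a step of no size beyond the scatter, most likely again ending at the limit; the estimated step that the limit leaves unreadable from compound 3 to compound 4 is expected to be flat. Compound 4 is estimated at 12 h, with a range from 6 h to 30 h.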

Compound 4, half-life: 4.02 h
Beside the measured number, compound 4's estimate is 3.0-fold (0.47 log units) above it, outside the stated range (below it).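

Where the earlier steps to compound 3 cannot be read, the carbon named here, a saturated chain carbon bound to a double-bonded chain carbon, now shows a readable response in this assay: methoxy in place of hydrogen gives an at least 2.1-fold lower number from compound 3 to compound 4 (0.32 log units; beyond the scatter), and methoxy in place of hydroxymethyl gives an at least 2.1-fold lower number from compound 1 to compound 4 (0.32 log units; beyond the scatter). Both steps start from a limit of the assay, so each gives only a minimum size, yet both lie beyond the scatter and show that the compound disappears faster with methoxy at this place. Compound 4 is the only compound shown that carries a number rather than a limit, so methoxy is the one group at this place that separates from the others: the limit of > 8.53 h in this assay, at which 3 of the 4 values shown sit.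

As far as these compounds go, the size of the full drop stays open, as does any order between hydrogen and hydroxymethyl at this place. Also open, from the compounds shown here alone, is whether ethoxy, an amine or a longer chain on the same carbon would follow methoxy or stay with hydrogen and hydroxymethyl, and whether the same change would act alike on the core of compound 2.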